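Swapping Chloro for Methyl on a Weak Inhibitor

This account rests on a few compounds, and the source may have more. Where it says the series, first, only, none or still open, it means among the compounds named here.

Compound 1 `Nc1nc2cc(Cl)c(Cl)cc2n1Cc1ccc(Cl)cc1` gives 45000 nM in a functional assay on KB cells (Homo sapiens) for inhibition; a lower number here means a stronger inhibitor, a higher number a weaker inhibitor. Compound 2 `Cc1ccc(Cn2c(N)nc3cc(Cl)c(Cl)cc32)cc1` gives 50000 nM, and the move a 1.1-fold higher number from compound 1 to compound 2 (0.05 log units; within the scatter) is small. Compound 3 `Clc1ccc(Cn2c(Cl)nc3cc(Cl)c(Cl)cc32)cc1` reaches only a limit of the assay, > 100000 nM, so no number is known for it. That move, an at least 2.2-fold higher number from compound 1 to compound 3 (0.34 log units; beyond the scatter), is the only one beyond the scatter here. Compound 4 `Cc1ccc(Cn2c(Cl)nc3cc(Cl)c(Cl)cc32)cc1` has not been measured; it differs from compound 3 by methyl in place of chloro on an aromatic carbon. The same exchange, from compound 1 to compound 2, gave a 1.1-fold higher number from compound 1 to compound 2 (0.05 log units; within the scatter), so a step that the limit leaves unreadable from compound 3 to compound 4 is expected, within the scatter. Compound 4 is therefore estimated at 150000 nM, between 70000 nM and 400000 nM, and most likely again reported only as a limit in this assay.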

Compound 4, half-maximal inhibitory concentration: > 100000 nM
Compound 4 was reported as a limit; the forecaster's own chance of this, stated with the estimate: 80%; the middle value does not contradict the limit.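

In this assay, compound 3 and compound 4 both stand at a limit, so the step between them cannot be read and methyl in place of chloro shows no measurable effect here. The new information concerns chloro in place of amino, which with the methyl group present gives an at least 2.0-fold higher number from compound 2 to compound 4 (0.30 log units; that floor lies within the scatter). This exchange has now been tested twice, with no sign yet of a difference between the two cases: the same change on two cores in this assay, an at least 2.2-fold higher number (0.34 log units; beyond the scatter) from compound 1 to compound 3 and an at least 2.0-fold higher number (0.30 log units; that floor lies within the scatter) from compound 2 to compound 4; the limit leaves it open whether they differ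

On these data alone, how weak compound 3 and compound 4 really are stays unknown, as both sit at the ceiling of the assay: the limit of > 100000 nM in this assay, at which 2 of the 4 values shown sit. It also remains open whether a methylamino or hydroxyl group in place of the amino would give a lower number.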